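The source may report more compounds than this note shows. Statements on the series, on what has been measured and on what is new or still open speak of the compounds shown alone.

Of the compounds shown here, two built on one shared core have been measured. Compound 1 `COc1cc2cc(Oc3ccc(NC(=O)Nc4cccc(C(F)(F)F)c4)cc3)c(C)nc2cc1OC` gives 5430 nM in a functional assay on MCF7 cells (Homo sapiens) for inhibition, read by sulforhodamine B assay, with a stated time of 48 h; a lower number here means a stronger inhibitor of growth, a higher number a weaker inhibitor of growth. Compound 2 `COc1cc2cc(Oc3ccc(NC(=O)Nc4ccc(Cl)c(C(F)(F)F)c4)cc3)c(C)nc2cc1OC` gives 3880 nM in this assay; the step of a 1.4-fold lower number from compound 1 to compound 2 (0.15 log units; within the scatter) separates the two, so on the numbers shown compound 2 sits beside compound 1 rather than apart from it.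

Compound 3 `COc1cc2cc(Oc3ccc(NC(=O)Nc4ccc(Cl)c(Cl)c4)cc3)c(C)nc2cc1OC` is the unmeasured analogue. Its difference from compound 2 is chloro in place of trifluoromethyl on an aromatic carbon, a swap of one small group for another on the outer ring of the urea. Going by the values given here, the only measured step, a 1.4-fold lower number from compound 1 to compound 2 (0.15 log units; within the scatter), concerns adding a chloro group where hydrogen had been, not exchanging trifluoromethyl for chloro, so no measured step bears directly on this change, and the one that exists was itself small. The expected step of a 1.2-fold higher number from compound 2 to compound 3 (0.06 log units; within the scatter) is therefore none beyond the scatter. Compound 3 is estimated at 4500 nM in this assay, with a range from 1500 nM to 13000 nM.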

Compound 3, concentration for total growth inhibition: 13800 nM
Beside the measured number, compound 3's estimate is 3.1-fold (0.49 log units) below it; measured number above the stated range.
By their numbers in this assay, from the lowest: compounds 2 and 1 (each within the scatter of the next); then compound 3.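

In this assay, going by these compounds alone, the exchange of trifluoromethyl for chloro on the outer ring is the first change here to move the number beyond the scatter, with a 3.6-fold higher number from compound 2 to compound 3 (0.55 log units; beyond the scatter) as its size. Compound 3 also stands apart from the analogue with a single substituent on that ring, with a 2.5-fold higher number from compound 1 to compound 3 (0.41 log units; beyond the scatter) as the gap, so both compounds carrying trifluoromethyl have lower numbers than the one without it, and none of the three goes against this. No supporting measurement is available to explain why this exchange raises the number.

The compounds shown leave open how a methyl group, a nitrile or a bromo group at this position would compare with trifluoromethyl and chloro. They also leave open whether the same step would appear on cells other than these.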